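The source may report more compounds than this note shows. Statements on the series, on what has been measured and on what is new or still open speak of the compounds shown alone.

Measured so far in a functional assay on FM3A cells (Mus musculus) for antiproliferative activity, with a stated time of 48 h; a lower number here means a stronger inhibitor, a higher number a weaker inhibitor: compound 1 `C=C(Br)C(=O)Nc1ccc(C(=O)/C=C/c2cccc(OC)c2)cc1` gives 1800 nM; compound 2 `C=C(Br)C(=O)Nc1ccc(C(=O)/C=C/c2ccc(OC)c(OC)c2)cc1` gives 1200 nM; compound 3 `Nc1ccc(/C=C/C(=O)c2ccccc2)cc1` gives 146000 nM.

Compounds 1 and 2 share a core; the change methoxy in place of hydrogen on an aromatic carbon gave a 1.5-fold lower number from compound 1 to compound 2 (0.18 log units; within the scatter). Compound 3 stands apart, and the difference between its core and that of compound 1 is not broken down here.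

Compound 4 `COc1cccc(C(=O)/C=C/c2ccc(N)cc2)c1` is not yet measured. It arises from compound 3 by methoxy in place of hydrogen on an aromatic carbon, the same kind of change as from compound 1 to compound 2, but not the same: there the entering group sits ortho to a methoxy group and para to a large group, here meta to a large group.

A step of about a 1.3-fold lower number from compound 3 to compound 4 (0.12 log units; within the scatter) is expected because a 1.5-fold lower number from compound 1 to compound 2 (0.18 log units; within the scatter) lay within the scatter. For compound 4 in this assay the estimate is 110000 nM, expected between 40000 nM and 300000 nM.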

Compound 4, half-maximal inhibitory concentration: 43000 nM
For compound 4 the middle estimate is 2.6-fold (0.41 log units) above the measured one; the range from low to high includes it.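

In this assay, methoxy in place of hydrogen on an aromatic carbon gave a 3.4-fold lower number from compound 3 to compound 4 (0.53 log units; beyond the scatter), a modest step. Set beside the earlier step, the two do not differ beyond the scatter: the same change on two cores in this assay, a 1.5-fold lower number (0.18 log units; within the scatter) from compound 1 to compound 2 and a 3.4-fold lower number (0.53 log units; beyond the scatter) from compound 3 to compound 4, 2.3-fold (0.35 log units) apart, within the scatter of two such steps. The change can therefore be carried between these two cores as a step of similar size, though the number fell beyond the scatter only on the core of compound 3, and one pair per core, with the entering group in different surroundings, shows nothing about any other core.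

Open, on these data alone, is whether a longer chain such as ethoxy, or a hydroxyl or an amine, in place of this methoxy would give a step of like size. Also open, as far as these compounds go, is whether methoxy would do the same at other ring positions.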